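Compound 1 at the Limit, Before Compound 3 Is Measured

This account rests on a few compounds, and the source may have more. Where it says the series, first, only, none or still open, it means among the compounds named here.

Compound 1 `C=C[C@@](C)(/C=C/c1ccc(Nc2ccc(OC)cc2)cc1)CCC=C(C)C` was tested in an ADME assay on HEK293 cells (Homo sapiens) for cytotoxicity, with a stated time of 72 h; a higher number here means that more compound is needed for the effect, a lower number that less compound is needed. In this assay compound 1 gives > 36600 nM, which is a limit of the assay and not a number. Compound 2 `C=C[C@@](C)(/C=C/c1ccc(Nc2c(F)cc(F)cc2F)cc1)CCC=C(C)C` shares the core of compound 1 and carries 2,4,6-trifluorophenyl in place of 4-methoxyphenyl on a nitrogen on an aromatic ring. In this assay compound 2 gives > 36600 nM, again a limit. The step that the two limits leave unreadable from compound 1 to compound 2 therefore cannot be read. Both values shown sit at the same limit (the limit of > 36600 nM in this assay, at which 2 of the 2 values shown sit), so compound 1 stands only at a bound, with no number to place it.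

Compound 3 `C=C[C@@](C)(/C=C/c1ccc(-c2ccc(Cl)cc2)cc1)CCC=C(C)C` has not yet been measured. It differs from compound 1 by 4-chlorophenyl in place of (4-methoxyphenyl)amino on an aromatic carbon. Within the data shown here, no measured step alters the (4-methoxyphenyl)amino group itself; the one step that exists keeps the nitrogen and changes only the ring on it, and it is unreadable. There is thus nothing to forecast a step of any size or direction in this assay beyond the scatter. Compound 3 is expected to give 40000 nM, with a range from 15000 nM to 100000 nM, most likely reported again as a limit. The expected step that the limit leaves unreadable from compound 1 to compound 3 is estimated to be close to none.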

Compound 3, half-maximal effective concentration: > 36600 nM
Compound 3: no number, only a limit; the forecaster's own chance of this, stated with the estimate: 70%; the middle value is on the limit's open side.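

In this assay compound 3 gives > 36600 nM, which is a limit and not a number. No step can be read between compound 1 and compound 3, because all the values sit together: the limit of > 36600 nM in this assay, at which 3 of the 3 values shown sit.

The compounds shown leave open what concentration of any of them produces the effect, and whether exchanging (4-methoxyphenyl)amino for 4-chlorophenyl changes it at all.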